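Methoxy in place of chloro, starting from a limit

This account rests on a few compounds, and the source may have more. Where it says the series, first, only, none or still open, it means among the compounds named here.

Compound 1 `C=CCn1c(=O)c(C=O)cc2ccccc21`: > 100000 nM, a limit
Compound 2 `C#CCn1c(=O)c(C=O)cc2cc(Cl)ccc21`: > 100000 nM, a limit

Both compounds were tested in a functional assay on MCF7 cells (Homo sapiens) for cytotoxicity, read by MTT assay, with a stated time of 24 h; on this read-out higher numbers stand for weaker inhibition and lower numbers for stronger inhibition. In this assay compound 2 gives > 100000 nM, which is a limit of the assay and not a number. Compound 2 therefore has no exact place on the scale, and compound 1 offers no exact value for comparison. What the two share is this: the limit of > 100000 nM in this assay, at which 2 of the 2 values shown sit.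

Compound 3 `C#CCn1c(=O)c(C=O)cc2cc(OC)ccc21` keeps the core of compound 2 and changes in one place, with methoxy in place of chloro on an aromatic carbon. Going by the values given here, no step between measured compounds is available to show how much such a change might matter. The expectation in this assay therefore rests only on what has been seen so far: the limit of > 100000 nM in this assay, at which 2 of the 2 values shown sit. The expected change is a number no higher from compound 2 to compound 3 (the limit leaves the size open), with none beyond the scatter. A report of only a limit is the expected outcome once more. For compound 3 the estimate is 100000 nM, with an expected range from 40000 nM to 200000 nM.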

Compound 3, half-maximal inhibitory concentration: > 100000 nM
Compound 3 gave a limit, no number; the forecaster's own chance of this, stated with the estimate: 85%; the middle value lies on the limit itself.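

In this assay compound 3 gives > 100000 nM, which is a limit of the assay and not a number. Compound 2 also stands at a limit, so no step from compound 2 to compound 3 can be read, and the three compounds share one result: the limit of > 100000 nM in this assay, at which 3 of the 3 values shown sit.

The compounds shown leave open whether methoxy in place of chloro changes the read-out at all, and whether any compound on this shared core reaches a measurable value in this assay.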